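Sulfonate ester in place of trifluoromethyl on compound 2

A few compounds are considered here, and "the series" means these few. Any claim that something is new, unique, unknown or untested is made for them only; others in the source may bear on it.

Of the compounds shown here, two have been measured in an assay on CHO-K1 cells with adenosine receptor A1 (Homo sapiens) as the target; a higher number here means that more compound is needed for the effect, a lower number that less compound is needed. Compound 1 `CCOC(=O)c1nn(-c2cccc(C(F)(F)F)c2)c(=O)c2c(N)scc12` gives 2700 nM there. Compound 2 `CCOC(=O)c1nn(-c2ccc(C(F)(F)F)cc2)c(=O)c2c(N)scc12` gives 8400 nM in this assay. Compound 2 thus stands at the higher of the two numbers; compound 1 is its nearest neighbour, with a number lower by a margin that lies beyond the usual scatter. For the measured compounds named here, the two measured compounds differ at more than one site, so no single-site step is available to guide the next move.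

Compound 3 `CCOC(=O)c1nn(-c2ccc(OS(=O)(=O)C(F)(F)F)cc2)c(=O)c2c(N)scc12` has not been measured. It differs from compound 2 in one place: ((trifluoromethyl)sulfonyl)oxy in place of trifluoromethyl on an aromatic carbon. Going by the values given here, the entering group differs from the leaving group in size and composition as counted, but no measured pair shows how such an exchange on this ring shifts the number in this assay. The expectation is therefore anchored on compound 2 with a wide range and no strong direction, most likely a step no further than the usual scatter. The expected step is a 1.1-fold lower number from compound 2 to compound 3 (0.02 log units; within the scatter). Compound 3 is estimated at 8000 nM, within 2500 nM to 25000 nM.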

Compound 3, half-maximal effective concentration: 4900 nM
Compound 3: middle estimate off by 1.6-fold (0.21 log units), on the high side; low and high end bracket the measured number.
By their numbers in this assay, from the lowest: compounds 1, 3 and 2 (each within the scatter of the next, the first and the last beyond it).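

In this assay, for the compounds shown here, the exchange of trifluoromethyl for ((trifluoromethyl)sulfonyl)oxy gives a 1.7-fold lower number from compound 2 to compound 3 (0.23 log units; within the scatter) and is the first single-site step available. On this aromatic carbon, para to a large group, the position accepts a substituent with more heavy atoms, two double bonds outside aromatic rings and hydrogen-bond acceptors that trifluoromethyl lacks, and the number still stays within the scatter. This one step therefore shows that the number need not respond to a substantial change in size and composition here, although it cannot define how much change the position tolerates.

Still open, going by these compounds, is whether an amine or a carboxylic acid on this carbon, in place of trifluoromethyl, would produce a step beyond the scatter, and whether the same exchange at the trifluoromethyl of compound 1 would give a similar step. No measured evidence bears on why this exchange gives the step it does.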